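This account rests on a few compounds, and the source may have more. Where it says the series, first, only, none or still open, it means among the compounds named here.

Compound 1 `CN(C)CCn1c(N)c(-c2nc3ccccc3[nH]2)c2nc(C#N)c(C#N)nc21` and compound 2 `CCN(CC)CCn1c(N)c(-c2nc3ccccc3[nH]2)c2nc(C#N)c(C#N)nc21` share one core and differ only in the amine at the end of the chain. In a functional assay on cells (Homo sapiens) for antiproliferative activity, read by MTT assay, with a stated time of 48 h (on this read-out higher numbers stand for weaker inhibition and lower numbers for stronger inhibition), compound 1 gives 43500 nM, and compound 2 gives 25400 nM. The change between them, (diethylamino in place of dimethylamino on a saturated chain carbon, two bonds along the chain from an aromatic nitrogen), produced a 1.7-fold lower number from compound 1 to compound 2 (0.23 log units; within the scatter); since this step lies within the scatter, the two values are best read as alike.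

Compound 3 `CN(C)CCCn1c(N)c(-c2nc3ccccc3n2C)c2nc(C#N)c(C#N)nc21` carries a different core, and the difference between the two cores is not broken down here. In this assay compound 3 gives 3670 nM, the lowest of the three numbers, with its steps to compound 2 and to compound 1 both beyond the scatter.

Compound 4 `CCN(CC)CCCn1c(N)c(-c2nc3ccccc3n2C)c2nc(C#N)c(C#N)nc21` is the counterpart of compound 3 in which the same kind of change is made, (diethylamino in place of dimethylamino on a saturated chain carbon, three bonds along the chain from an aromatic nitrogen). The place differs in that the amine now sits three bonds along the chain from the aromatic nitrogen rather than two. Going by the values given here, the only guide to its size is the earlier step, which was within the scatter, so compound 4 is expected to sit close to compound 3, with an estimated step of a 1.4-fold lower number from compound 3 to compound 4 (0.13 log units; within the scatter) in this assay. On that basis compound 4 is estimated at 2700 nM in this assay, with an expected range from 1200 nM to 6500 nM.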

Compound 4, half-maximal inhibitory concentration: 6750 nM
Estimate against measurement, compound 4: 2.5-fold (0.40 log units) below; the measured number lies above the stated range.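

In this assay, putting diethylamino in place of dimethylamino gave a 1.8-fold higher number from compound 3 to compound 4 (0.26 log units; within the scatter), so compound 3 and compound 4 are best read as alike, just as compound 1 and compound 2 are. Each step is small on its own, yet set side by side they run in opposite directions and do not match as a carried-over change: the same change on two cores in this assay, a 1.7-fold lower number (0.23 log units; within the scatter) from compound 1 to compound 2 and a 1.8-fold higher number (0.26 log units; within the scatter) from compound 3 to compound 4, 3.1-fold (0.50 log units) apart, beyond the scatter of two such steps This shows that the step measured on the core of compound 1 did not serve as a reliable guide to its size on the core of compound 3, but it does not show why, for the two pairs differ both in the core and in the chain, 2-(diethylamino)ethyl in one and 3-(diethylamino)propyl in the other, and these four compounds cannot separate those two differences.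

The compounds shown leave open how the same change behaves when the 2-(dialkylamino)ethyl chain sits on the core of compound 3, or the propyl chain on the core of compound 1. They also leave open what a cyclic amine or a still longer chain would do in either series.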